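This account rests on a few compounds, and the source may have more. Where it says the series, first, only, none or still open, it means among the compounds named here.

Measured compounds:
- compound 1 `Cc1ccc(CNC(=O)CN2C(=O)/C(=C/c3ccc(-c4ccc(Cl)cc4)o3)SC2=S)cc1` gives 45000 nM in a functional assay on K562 cells (Homo sapiens) for cytotoxicity, read by MTT assay, with a stated time of 72 h; on this read-out lower numbers stand for stronger inhibition and higher numbers for weaker inhibition
- compound 2 `O=C(CN1C(=O)/C(=C/c2ccc(-c3ccc(Cl)cc3)o2)SC1=S)NCc1ccc(Br)cc1` gives 68000 nM in this assay

Compound 2 holds the highest of the two numbers in this assay; its nearest neighbour is compound 1, and the step of a 1.5-fold higher number from compound 1 to compound 2 (0.18 log units; within the scatter) lies within the scatter, so the two cannot be placed in order. Compound 3 `CCCNC(=O)CN1C(=O)/C(=C/c2ccc(-c3ccc(Cl)cc3)o2)SC1=S` has not been measured in this assay. It differs from compound 2 in one place: ethyl in place of 4-bromophenyl on a saturated chain carbon bound to an amide-type nitrogen, which cut one bond further out reads 4-bromobenzyl to propyl.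

Within the data shown here, no measured step touches this change. Among the measured compounds shown here, the only step on record, from compound 1 to compound 2, swaps one substituent on the aromatic ring for another and stays within the scatter; it says nothing about removing the ring altogether. With both measured compounds sitting at weak inhibition, the expectation for compound 3 is a number near that of compound 2, with a step of a 1.1-fold lower number from compound 2 to compound 3 (0.05 log units; within the scatter) not reaching beyond the scatter. Compound 3 is therefore estimated at 60000 nM in this assay, within a range from 25000 nM to 150000 nM.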

Compound 3, half-maximal inhibitory concentration: 50000 nM
For compound 3 the middle estimate is 1.2-fold (0.08 log units) above the measured one; measured number inside the range.
By their numbers in this assay, from the lowest: compounds 1, 3 and 2 (each within the scatter of the next).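

In this assay, exchanging the 4-bromophenyl on the saturated chain carbon bound to an amide-type nitrogen for ethyl, which takes the aromatic ring out of the side chain altogether, gives a 1.4-fold lower number from compound 2 to compound 3 (0.13 log units; within the scatter), and the same exchange starting from 4-methylphenyl gives a 1.1-fold higher number from compound 1 to compound 3 (0.05 log units; within the scatter). The earlier step had touched only a substituent on that ring, whereas these two steps show that across the three compounds shown, propyl cannot be told apart from either substituted benzyl group at this position, so the ring is not required for the number seen here. No measurement at hand bears on why these numbers stay so close together.

As far as these compounds go, what a hydrogen-bonding or charged group would do at this position remains open: an amine, a carboxylic acid or a longer chain in place of propyl could stay within the scatter or move beyond it. The compounds shown also share the rest of their structure, so they leave open whether any change in the shared core would give a step beyond the scatter in this assay.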